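This account rests on a few compounds, and the source may have more. Where it says the series, first, only, none or still open, it means among the compounds named here.

Compound 1 `Cc1cc(O)c(C2=NN(c3ccc(S(N)(=O)=O)cc3)C(c3ccccc3Cl)C2)cc1Cl` gives 3430 nM in a functional assay on M14 cells (Homo sapiens) for antiproliferative activity, with a stated time of 48 h; a higher number here means a weaker inhibitor of growth, a lower number a stronger inhibitor of growth. Compound 2 `Cc1cc(O)c(C2=NN(c3ccc(S(N)(=O)=O)cc3)C(/C=C/c3ccccc3)C2)cc1Cl` gives 19300 nM in this assay, the highest of the two numbers, reached by a 5.6-fold higher number from compound 1 to compound 2 (0.75 log units; beyond the scatter). Compound 3 `COc1ccc(C2CC(c3cc(Cl)c(C)cc3O)=NN2c2ccc(S(N)(=O)=O)cc2)c(OC)c1OC` is not yet measured; it differs from compound 2 by 2,3,4-trimethoxyphenyl in place of 2-phenylethenyl on a saturated ring carbon. Within the data shown here, only the step from compound 1 to compound 2 bears on this change, and it ran the other way from an aromatic group to the phenylethenyl, so a return toward an aromatic group suggests a lower number, though the entering group is not the one that left. Compound 3 is therefore expected to show a 3.0-fold lower number from compound 2 to compound 3 (0.47 log units; beyond the scatter), with an estimated value of 6500 nM within 1800 nM to 24000 nM.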

Compound 3, concentration for total growth inhibition: 4290 nM
The estimate for compound 3 lay 1.5-fold (0.18 log units) above the measured number, within the range that was stated.
By their numbers in this assay, from the lowest: compounds 1 and 3 (each within the scatter of the next); then compound 2.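

In this assay, 2,3,4-trimethoxyphenyl on the saturated ring carbon gives a 4.5-fold lower number from compound 2 to compound 3 (0.65 log units; beyond the scatter) and thus shows that an aromatic group other than 2-chlorophenyl also stands apart from 2-phenylethenyl. Against 2-chlorophenyl, the same group gives a 1.3-fold higher number from compound 1 to compound 3 (0.10 log units; within the scatter) and cannot be told from it here, despite its three methoxy groups. No evidence is available to explain these steps. The compounds shown leave open whether a single methoxy group on the phenyl would match the trimethoxy pattern, and how a cyclohexyl group or an aminomethyl group would fare at this position.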